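The source may hold more compounds than are shown below. What is called first, only, known or untested is meant among the compounds shown, and "the series" means these compounds.

Compound 1 `Cc1cccc(C(=O)c2c(OCC(=O)Nc3ccc(S(N)(=O)=O)cc3C)ccc3ccccc23)c1` gives 40400 nM in an ADME assay on C8166 cells (Homo sapiens) for cytotoxicity, read by colorimetric assay and MTT assay; on this read-out lower numbers stand for higher toxicity in this test and higher numbers for lower toxicity in this test.
Compound 2 `Cc1cc(S(N)(=O)=O)ccc1NC(=O)COc1ccc2ccccc2c1C(=O)c1cccc(Cl)c1` gives 37400 nM in this assay.
Compound 3 `Cc1ccc(C(=O)c2c(OCC(=O)Nc3ccc(S(N)(=O)=O)cc3C)ccc3ccccc23)c(C)c1` gives 25500 nM in this assay.

Compound 3 has the lowest of the three numbers in this assay, but its nearest neighbour is compound 2 and the step from compound 2 to compound 3 is a 1.5-fold lower number from compound 2 to compound 3 (0.17 log units; within the scatter), and the step from compound 1 to compound 3 is a 1.6-fold lower number from compound 1 to compound 3 (0.20 log units; within the scatter); neither separates it from the others beyond the scatter. Compound 4 `Cc1cc(S(N)(=O)=O)ccc1NC(=O)COc1ccc2ccccc2c1C(=O)c1cc(Cl)cc(C#N)c1` differs from compound 3 by 3-chloro-5-cyanophenyl in place of 2,4-dimethylphenyl on a carbonyl carbon. Among the measured compounds shown here, the steps that bear on this place are the two just named, both changes of the aryl on the carbonyl carbon, and both stayed within the scatter, as did the ring substituent exchange from compound 1 to compound 2, a 1.1-fold lower number from compound 1 to compound 2 (0.03 log units; within the scatter). For the measured compounds named here, no measured compound carries a nitrile, so the new group enters untested ground. The step from compound 3 to compound 4 in this assay is therefore expected to be a 1.2-fold higher number from compound 3 to compound 4 (0.07 log units; within the scatter), with no direction beyond the scatter. Compound 4 is estimated at 30000 nM, in the range 15000 nM to 60000 nM.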

Compound 4, half-maximal cytotoxic concentration: 49400 nM
Compound 4: middle estimate off by 1.6-fold (0.22 log units), on the low side; the measured number falls inside the stated range.
By their numbers in this assay, from the lowest: compounds 3, 2, 1 and 4 (each within the scatter of the next).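

In this assay, cyano in place of hydrogen on an aromatic carbon of the aryl gives (a 1.3-fold higher number from compound 2 to compound 4 (0.12 log units; within the scatter)), so the one nitrile in the set does not separate compound 4 from the compound that lacks it. Replacing the whole aryl on the carbonyl carbon gives (a 1.2-fold higher number from compound 1 to compound 4 (0.09 log units; within the scatter)) and (a 1.9-fold higher number from compound 3 to compound 4 (0.29 log units; within the scatter)), which extends the earlier picture: this position has now carried four aryl groups bearing methyl, chloro or cyano, and every step between them stays within the scatter. Nothing measured bears on why these steps are small.

As far as these compounds go, whether an aryl bearing an amine or a carboxylic acid would give a step beyond the scatter remains open. So does the result of a saturated cyclohexyl group in place of the aryl on the carbonyl carbon.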